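The source may report more compounds than this note shows. Statements on the series, on what has been measured and on what is new or still open speak of the compounds shown alone.

Three compounds have been measured in a functional assay on KB cells (Homo sapiens) for inhibition; on this read-out higher numbers stand for weaker inhibition and lower numbers for stronger inhibition:

- compound 1 `CCOC[C@H]1O[C@@H](n2c(Cl)nc3cc(Cl)c(Cl)cc32)[C@H](OC(C)=O)[C@@H]1OC(C)=O`: 60000 nM
- compound 2 `CC(=O)OC1C(CBr)OC(n2c(Cl)nc3cc(Cl)c(Cl)cc32)C1OC(C)=O`: 60000 nM
- compound 3 `COC[C@H]1OC(n2c(Cl)nc3cc(Cl)c(Cl)cc32)[C@H](O)[C@@H]1O`: 90000 nM

Compound 3, at 90000 nM, lies within the scatter of both compound 1 and compound 2, so this assay does not separate these three compounds. The next compound, compound 4 `CSC[C@H]1OC(n2c(Cl)nc3cc(Cl)c(Cl)cc32)[C@H](O)[C@@H]1O`, keeps the shared core of compound 3 and carries methylsulfanyl in place of methoxy on a saturated chain carbon bound to a saturated ring carbon.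

Among the measured compounds shown here, no measured pair differs in one place only, so the data give no direct reading of this change. The best guide is compound 3 at 90000 nM, together with compound 1 at 60000 nM and compound 2 at 60000 nM, which agree within the scatter although their structures differ in several places. No change beyond the scatter is therefore expected, and the estimated step is a 1.3-fold lower number from compound 3 to compound 4 (0.11 log units; within the scatter). For compound 4 the estimated value is 70000 nM, with an expected range from 30000 nM to 120000 nM.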

Compound 4, half-maximal inhibitory concentration: > 100000 nM
Compound 4: a limit, no number; the forecaster's own chance of this, stated with the estimate: 15%; at least 1.4-fold (0.15 log units) between middle value and limit.
By their numbers in this assay, from the lowest: compounds 1, 2 and 3 (each within the scatter of the next). At a limit, above all of these: compound 4.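

Compound 4 gives > 100000 nM in this assay, and this is a limit, not a number. Among the compounds shown here, the exchange of methoxy for methylsulfanyl on a saturated chain carbon bound to a saturated ring carbon is the first change that can be read in one place only, and it gives an at least 1.1-fold higher number from compound 3 to compound 4 (0.04 log units; that floor lies within the scatter), so methylsulfanyl brings no stronger inhibition than methoxy here. On these data alone, how far the number of compound 4 lies past that floor stays unknown, because the result is a limit: the limit of > 100000 nM in this assay, at which 1 of the 4 values shown sits.

The compounds shown leave open how an amine, a carboxylic acid or a longer chain in place of methoxy would read against compound 3. They also leave open whether any replacement at this position gives a number beyond the scatter of compound 3.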